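Methoxymethyl on an Oxygen of Compound 2

The source may report more compounds than this note shows. Statements on the series, on what has been measured and on what is new or still open speak of the compounds shown alone.

Of the compounds shown here, two with the same long unsaturated chain have been measured in a functional assay on MCF7 cells (Homo sapiens) for antiproliferative activity, read by MTT assay; on this read-out higher numbers stand for weaker inhibition and lower numbers for stronger inhibition. Compound 1 (`CC/C=C\C/C=C\C/C=C\CCCCCCCc1cc(=O)c2c(O)cc(O)cc2o1`) gives 17500 nM, and compound 2 (`CC/C=C\C/C=C\C/C=C\CCCCCCCc1cc(=O)c2c(O)c(C)c(O)cc2o1`) gives 17500 nM, so compound 2 stands level with compound 1. The next structure, compound 3 (`CC/C=C\C/C=C\C/C=C\CCCCCCCc1cc(=O)c2c(O)c(C)c(OCOC)cc2o1`), keeps everything in compound 2 except one hydroxy group, which becomes methoxymethoxy: methoxymethyl in place of hydrogen on an oxygen on an aromatic ring. This is methoxymethyl in place of hydrogen on an oxygen on an aromatic ring.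

Among the compounds with values here, only one measured step bears on this change, and only loosely. The step of no change at the digits printed from compound 1 to compound 2 (within the scatter) stayed within the scatter, but it placed methyl on an aromatic carbon and left the oxygen untouched. The data therefore contain no direct test of replacing that hydrogen. Within the data shown here, with this single flat step as the only guide, no shift beyond the scatter is expected in this assay, though the uncertainty is wide in both directions. The expected change is a 1.1-fold higher number from compound 2 to compound 3 (0.06 log units; within the scatter). For compound 3 the estimated value is 20000 nM, with an expected range from 8000 nM to 50000 nM.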

Compound 3, half-maximal inhibitory concentration: 17500 nM
Estimate against measurement, compound 3: 1.1-fold (0.06 log units) above; low and high end bracket the measured number.
By their numbers in this assay, from the lowest: compounds 1, 2 and 3 (each within the scatter of the next).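

In this assay, replacing the hydrogen of this hydroxy group with methoxymethyl gives no change at the digits printed from compound 2 to compound 3 (within the scatter), so the free hydroxy hydrogen at this oxygen on the aromatic ring is not needed to hold the value seen for compound 2. Within the data shown here, this is the first change at an oxygen, whereas the earlier step, no change at the digits printed from compound 1 to compound 2 (within the scatter), concerned an aromatic carbon and left this question untouched. Both single changes now leave the number level, with no compound among the three going against that, but no measured evidence is available on why the value holds at this oxygen.

Whether a benzyl group or a chain ending in an amine on the same oxygen would also leave the number level remains open, since methoxymethyl is the only group shown there. Also open, from the compounds shown here alone, are the effects of a methyl or acetyl group on the remaining hydroxy oxygen and of a shorter chain, or a carboxylic acid at the end of the long unsaturated chain, in place of the present chain.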